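This account rests on a few compounds, and the source may have more. Where it says the series, first, only, none or still open, it means among the compounds named here.

Of the compounds shown here, three built on one shared core have been measured in an ADME assay on microsomes from liver (Homo sapiens) for metabolic stability, tested at 2.5 uM; a higher number here means faster removal of the compound, a lower number slower removal. Compound 1 `O=S(=O)(c1ccc(F)c(F)c1)c1cnc2cc(F)ccc2c1-c1cccc(Cl)c1` gives 0.38 mL/min, compound 2 `O=S(=O)(c1cc(Cl)cc(Cl)c1)c1cnc2cc(F)ccc2c1-c1ccc(F)cc1` gives 0.18 mL/min, and compound 3 `Cc1ccc(S(=O)(=O)c2cnc3cc(F)ccc3c2-c2cccc(Cl)c2)cc1C` gives 4.01 mL/min. Compound 3 thus stands highest of the three: its nearest neighbour is compound 1 and the furthest is compound 2, and both gaps lie beyond the scatter. For the measured compounds named here, the one measured step that changes a single place is an 11-fold higher number from compound 1 to compound 3 (1.02 log units; beyond the scatter), in which a 3,4-dimethylphenyl took the place of a 3,4-difluorophenyl on a sulfonyl sulfur. Compound 4 `O=S(=O)(c1cc(Cl)cc(Cl)c1)c1cnc2cc(F)ccc2c1-c1cccc(Cl)c1` now makes the change (3,5-dichlorophenyl in place of 3,4-dimethylphenyl on a sulfonyl sulfur). Compound 2 already carries a 3,5-dichlorophenyl on its sulfonyl sulfur and sits low in this assay. Going by the values given here, with the dimethyl-to-difluoro step as the only guide to size, a reversal of roughly that magnitude is expected, so a large fall is expected, a 13-fold lower number from compound 3 to compound 4 (1.13 log units; beyond the scatter). Compound 4 is therefore estimated at 0.3 mL/min, between 0.1 mL/min and 0.9 mL/min.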

Compound 4, intrinsic clearance in a liver preparation (reported as CLH), per the amount of preparation that the assay uses: 0.93 mL/min
Compound 4: the middle estimate sits 3.1-fold (0.49 log units) below what was measured, and the stated range ends below it.
By their numbers in this assay, from the lowest: compound 2; then compound 1; then compound 4; then compound 3.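

On the sulfonyl sulfur, 3,5-dichlorophenyl in place of 3,4-dimethylphenyl gives a 4.3-fold lower number from compound 3 to compound 4 (0.63 log units; beyond the scatter) in this assay, a smaller fall than the one seen with 3,4-difluorophenyl, and the two halogen-bearing groups are not interchangeable, since the change from difluoro to dichloro gives a 2.4-fold higher number from compound 1 to compound 4 (0.39 log units; beyond the scatter). The sulfur is also not the only place that matters: with 3,5-dichlorophenyl held fixed there, 3-chlorophenyl in place of 4-fluorophenyl on an aromatic carbon gives a 5.2-fold higher number from compound 2 to compound 4 (0.71 log units; beyond the scatter). Nothing available explains why either position moves these numbers.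

Between compound 1 and compound 4, the kind of halogen and its ring positions change together, so their separate contributions remain unknown. Going by these compounds, it also remains open how a group of another type on the sulfonyl sulfur, such as an amine-bearing ring or a longer alkyl chain, would behave.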